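A Second Aryl Swap on a Weakly Antiproliferative Core

This account rests on a few compounds, and the source may have more. Where it says the series, first, only, none or still open, it means among the compounds named here.

Among the measured compounds shown here, compound 1 `N#CC1=C(N)Oc2c(c3nc4ccccc4nc3c3ccccc23)C12C(=O)N(Cc1cnnn1-c1ccccc1Cl)c1ccccc12` sits at 42600 nM in a functional assay on A549 cells (Homo sapiens) for antiproliferative activity, read by MTT assay, with a stated time of 48 h (on this read-out lower numbers stand for stronger inhibition and higher numbers for weaker inhibition), the only plain number here. Compound 2 `Cc1ccc(-n2nncc2CN2C(=O)C3(C(C#N)=C(N)Oc4c3c3nc5ccccc5nc3c3ccccc43)c3ccccc32)cc1Cl` reaches only the assay limit, > 50000 nM. The step of an at least 1.1-fold higher number from compound 1 to compound 2 (0.06 log units; that floor lies within the scatter) therefore tells little, resting on (the limit of > 50000 nM in this assay, at which 1 of the 2 values shown sits). Compound 3 `N#CC1=C(N)Oc2c(c3nc4ccccc4nc3c3ccccc23)C12C(=O)N(Cc1cnnn1-c1ccc(F)c(Cl)c1)c1ccccc12` differs from compound 1 by 3-chloro-4-fluorophenyl in place of 2-chlorophenyl on an aromatic nitrogen. For the measured compounds named here, the one comparable step, from compound 1 to compound 2, showed no change beyond the scatter, so compound 3 is expected to stay weak, with an estimated step of a 1.2-fold higher number from compound 1 to compound 3 (0.07 log units; within the scatter). Compound 3 is thus estimated at 50000 nM, within 25000 nM to 100000 nM, and may itself only reach the assay limit.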

Compound 3, half-maximal inhibitory concentration: > 50000 nM
Compound 3 gave a limit, no number (the forecaster's own chance of this, stated with the estimate: 50%); the middle value lies on the limit itself.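

At this position, swapping the 2-chlorophenyl for 3-chloro-4-fluorophenyl gives an at least 1.1-fold higher number from compound 1 to compound 3 (0.06 log units; that floor lies within the scatter), so a second replacement aryl group also shows no stronger inhibition in this assay. The step from methyl to fluoro between compound 2 and compound 3 cannot be read, as neither compound has a plain number, and the set now gathers at its ceiling: the limit of > 50000 nM in this assay, at which 2 of the 3 values shown sit.

As far as these compounds go, it remains open whether an amine or a carboxylic acid on this phenyl ring, or a simple alkyl chain in its place, would bring the value clearly under that limit. How far compound 2 and compound 3 lie beyond the limit is also unknown.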